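Methoxy to hydroxy: from compound 2 to compound 4

The compounds below may be only part of what the source reports. "The series", "measured", "known", "first", "only" and "open" are said of these compounds alone.

Of the compounds shown here, three on a shared core have been measured. Compound 1 `COc1cc(C)cc(-c2c(-c3ccnc(-c4ccc(N(C)C)cc4)c3)cnn2CC#N)c1`, compound 2 `COc1cc(C)cc(-c2nn(CC#N)cc2-c2ccnc(-c3ccc(N(C)C)cc3)c2)c1` and compound 3 `COc1cc(C)cc(-c2nn(CC#N)cc2-c2ccc(-c3cccc(C(C)=O)c3)nc2)c1` were each run in a functional assay on DU-145 cells (Homo sapiens) for cytotoxicity, read by sulforhodamine B assay, with a stated time of 48 h, tested at 10 uM; a higher number here means a weaker effect of the compound at the concentration tested, a lower number a stronger effect. Compound 1 gives -48%, compound 2 gives -48% and compound 3 gives -48%, so the three readings are level and within the scatter of one another. Compound 2 therefore stands level with compound 1 and with compound 3 in this assay; nothing among the three separates one from another.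

Compound 4 `Cc1cc(O)cc(-c2nn(CC#N)cc2-c2ccnc(-c3ccc(N(C)C)cc3)c2)c1` is not yet measured. Against compound 2 the difference is hydrogen in place of methyl on an oxygen on an aromatic ring. Going by the values given here, no step between measured compounds exists to size this change, so the expectation is a move of no more than the scatter, in no particular direction. For compound 4 the value expected in this assay is -46%, within -65% to -25%. The expected step of a number 2 percentage points higher from compound 2 to compound 4 (within the scatter) is none beyond the scatter.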

Compound 4, a percentage reported as activity, at one concentration (the size of the read-out at that concentration, not a potency): -66%
Estimate against measurement, compound 4: 20 percentage points above; the whole stated range lies above it.
By their numbers in this assay, from the lowest: compound 4; then compounds 1, 2 and 3 (each within the scatter of the next).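

Replacing methoxy with hydroxy on the 3-methoxy-5-methylphenyl group gives a number 18 percentage points lower from compound 2 to compound 4 (beyond the scatter) in this assay, with a lower number meaning a stronger effect. Going by these compounds alone, this is the first sized step and shows that the group on this oxygen can alter the read-out. Nothing available explains the shift.

From the compounds shown here alone, whether an amine or a carboxylic acid in place of the hydroxy would keep the stronger effect remains open. Also open, going by these compounds, is whether the same change would give a similar step on compound 1 or compound 3.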